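This account rests on a few compounds, and the source may have more. Where it says the series, first, only, none or still open, it means among the compounds named here.

Measured so far, in a functional assay on ECa-109 cells (Homo sapiens) for cytotoxicity, read by MTT assay, with a stated time of 72 h; on this read-out higher numbers stand for weaker inhibition and lower numbers for stronger inhibition:

Compound 1, `CCC(C)=C1C(=O)N(c2ccc(Cl)cc2)N(c2ccc(Cl)cc2)C1=O`, gives 41100 nM.
Compound 2, `COc1cccc(C=C2C(=O)N(c3ccc(Cl)cc3)N(c3ccc(Cl)cc3)C2=O)c1O`, gives 39000 nM.
Compound 3, `COc1ccc(C=C2C(=O)N(c3ccc(Cl)cc3)N(c3ccc(Cl)cc3)C2=O)cc1`, reaches only a limit of the assay, > 128000 nM.

Among these, compound 2 gives the lowest number, though compound 1 sits within the usual scatter of it, so the two cannot be put in order. Compound 3 sits at the limit of > 128000 nM in this assay, at which 1 of the 3 values shown sits, and is only known to be weaker.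

The step considered here leads from compound 2 to compound 4, `O=C1C(=Cc2ccccc2)C(=O)N(c2ccc(Cl)cc2)N1c1ccc(Cl)cc1`. The change is phenyl in place of 2-hydroxy-3-methoxyphenyl on a double-bonded chain carbon bound to a double-bonded ring carbon.

For the measured compounds named here, the one measured step that bears on it is an at least 3.2-fold higher number from compound 2 to compound 3 (0.51 log units; beyond the scatter), where the 2-hydroxy-3-methoxyphenyl group was also replaced, there by 4-methoxyphenyl. Since phenyl likewise lacks the hydroxy and methoxy groups of compound 2, a step in the same direction is expected: a higher number, likely beyond the scatter, with a fair chance that only a limit is reported. The expected step is a 3.1-fold higher number from compound 2 to compound 4 (0.49 log units; beyond the scatter), so compound 4 is estimated at 120000 nM in this assay, ranging from 45000 nM to 320000 nM.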

Compound 4, half-maximal inhibitory concentration: 32700 nM
Compound 4: middle estimate off by 3.7-fold (0.56 log units), on the high side; measured number outside the range, below it.
By their numbers in this assay, from the lowest: compounds 4, 2 and 1 (each within the scatter of the next). At a limit, above all of these: compound 3.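

In this assay, plain phenyl on the double-bonded chain carbon holds the same level as 2-hydroxy-3-methoxyphenyl (a 1.2-fold lower number from compound 2 to compound 4 (0.08 log units; within the scatter)), so compound 2 does not need its hydroxy and methoxy groups to reach this level. The weak result of compound 3 therefore cannot be read as the loss of those groups, and with hydrogen in place of methoxy on an aromatic carbon the number falls (an at least 3.9-fold lower number from compound 3 to compound 4 (0.59 log units; beyond the scatter)), which points to the methoxy group carried by compound 3 as the feature that sets it apart. Going by these compounds, the true size of that step remains unknown, as compound 3 gives only a limit of the assay: the limit of > 128000 nM in this assay, at which 1 of the 4 values shown sits.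

Still open, on these data alone, is whether a lone hydroxy group or a lone methoxy group on the phenyl of compound 4 would behave like compound 2 or like compound 3. The compounds shown also say nothing about an amine or a carboxylic acid on that ring.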